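This account rests on a few compounds, and the source may have more. Where it says the series, first, only, none or still open, it means among the compounds named here.

Measured so far in a functional assay on PC-3 cells (Homo sapiens) for inhibition, read by sulforhodamine B assay, with a stated time of 48 h, tested at 10 uM; a lower number here means less inhibition, a higher number more inhibition at the concentration tested (going by the name of the read-out):
- compound 1 `COc1ccc(-c2cn3ccnc3c(-c3ccc4ncn(C5CCCCC5)c4c3)n2)cc1`: 95.2%
- compound 2 `O=Cc1ccc(-c2cn3ccnc3c(-c3ccc4ncn(C5CCCCC5)c4c3)n2)cc1`: 19%
- compound 3 `c1ccc2c(-c3cn4ccnc4c(-c4ccc5ncn(C6CCCCC6)c5c4)n3)cccc2c1`: 36.5%

Compound 3 stands second highest of the three numbers in this assay; its nearest neighbour is compound 2, and its furthest is compound 1, the step of a number 17.5 percentage points higher from compound 2 to compound 3 (beyond the scatter) being modest and the step of a number 58.7 percentage points lower from compound 1 to compound 3 (beyond the scatter) large. Compound 4 `Fc1ccc(-c2cn3ccnc3c(-c3ccc4ncn(C5CCCCC5)c4c3)n2)cc1` is not yet measured. The change is 4-fluorophenyl in place of naphthalen-1-yl on an aromatic carbon, a return to a single six-membered carbon ring bearing one substituent, as in compound 1 and compound 2. Within the data shown here, two measured steps bear on it: a number 58.7 percentage points lower from compound 1 to compound 3 (beyond the scatter) shows that leaving a substituted phenyl for naphthalen-1-yl lowered the number strongly, while a number 17.5 percentage points higher from compound 2 to compound 3 (beyond the scatter) shows the opposite direction at modest size. Among the measured compounds shown here, the substituent on the phenyl thus decides between a large rise and a modest fall, and no fluorine-bearing compound has been measured. A step of a number 18.5 percentage points higher from compound 3 to compound 4 (beyond the scatter) is therefore expected, upward, with wide uncertainty. The estimate for compound 4 in this assay is 55%, ranging from 15% to 95%.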

Compound 4, a percentage reported as inhibition, at one concentration (the size of the read-out at that concentration, not a potency): 53.6%
Estimate against measurement, compound 4: 1.4 percentage points above, within the range that was stated.
By their numbers in this assay, from the lowest: compound 2; then compound 3; then compound 4; then compound 1.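

In this assay, the step of a number 17.1 percentage points higher from compound 3 to compound 4 (beyond the scatter) shows that returning from naphthalen-1-yl to a substituted phenyl does not fix the outcome at this position: compound 1 and compound 4 stand above compound 3, while compound 2, also a substituted phenyl, stands below it. The substituent on the phenyl carries much of the spread, since the step of a number 34.6 percentage points higher from compound 2 to compound 4 (beyond the scatter) and the step of a number 41.6 percentage points lower from compound 1 to compound 4 (beyond the scatter) are both large and run in opposite directions. Fluoro therefore gives an intermediate result, well short of methoxy but clearly ahead of formyl.

No available evidence accounts for this order of methoxy, fluoro and formyl. Also open, going by these compounds, is where an amine, a carboxylic acid or a longer alkoxy chain in place of fluoro would fall on the same scale.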